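Swapping Chloro for Methoxy on a Pyrazole Enaminone

The compounds below may be only part of what the source reports. "The series", "measured", "known", "first", "only" and "open" are said of these compounds alone.

Measured so far:
Compound 1 `O=C(/C=C\Nc1ccc(Cl)cc1)c1cn(-c2ccccc2)nc1-c1ccc(Cl)cc1` gives 4650 nM in a functional assay on HT-29 cells (Homo sapiens) for antiproliferative activity, read by MTT assay, with a stated time of 48 h; on this read-out higher numbers stand for weaker inhibition and lower numbers for stronger inhibition.
Compound 2 `O=C(/C=C\Nc1ccc(O)cc1)c1cn(-c2ccccc2)nc1-c1ccc(Cl)cc1` gives 2500 nM in this assay.

For the measured compounds named here, compound 2 holds the lower of the two numbers, but its only neighbour is compound 1, and the step of a 1.9-fold lower number from compound 1 to compound 2 (0.27 log units; within the scatter) stays within the scatter, so the two cannot be ranked.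

Compound 3 `COc1ccc(-c2nn(-c3ccccc3)cc2C(=O)/C=C\Nc2ccc(O)cc2)cc1` is not yet measured. It differs from compound 2 by methoxy in place of chloro on an aromatic carbon. Going by the values given here, no measured step touches this part of the shared core: the one known step concerns a different ring, and it was within the scatter anyway. There is therefore nothing to support a shift in either direction in this assay, and no step beyond the scatter is expected, so the change a 1.1-fold higher number from compound 2 to compound 3 (0.03 log units; within the scatter) is an estimate with wide uncertainty. Compound 3 is estimated at 2700 nM, in the range 900 nM to 8000 nM.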

Compound 3, half-maximal inhibitory concentration: 2460 nM
The estimate for compound 3 lay 1.1-fold (0.04 log units) above the measured number, and the stated range covers the measured number.
By their numbers in this assay, from the lowest: compounds 3, 2 and 1 (each within the scatter of the next).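

Replacing 4-chlorophenyl with 4-methoxyphenyl gives a 1.0-fold lower number from compound 2 to compound 3 (0.01 log units; within the scatter) in this assay, so compound 2 and compound 3 cannot be told apart. The earlier step concerned a different ring, whereas this one shows that, at the aromatic carbon para to a large group, methoxy, which carries a hydrogen-bond acceptor, gives a number indistinguishable from that of chloro, which carries none. Nothing measured here offers an explanation for this result.

From the compounds shown here alone, whether an amine, a carboxylic acid or a longer chain such as butoxy at this place would move the number beyond the scatter remains open. Going by these compounds, it is also open whether the same swap would read alike with chloro rather than hydroxy on the other ring.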